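A few compounds are considered here, and "the series" means these few. Any claim that something is new, unique, unknown or untested is made for them only; others in the source may bear on it.

In a functional assay on HCT-116 cells (Homo sapiens) for inhibition, read by MTT assay, with a stated time of 48 h (a lower number here means a stronger inhibitor, a higher number a weaker inhibitor), compound 3 `COc1ccc(N(C)c2nc(C)nc3ccccc23)cc1OCC[Se]C#N` gives 18 nM and compound 1 `COc1ccc(N(C)c2nc(C)nc3ccccc23)cc1[Se]C` gives 28 nM, two values within the scatter of each other. Compound 2 `COc1ccc(N(C)c2nc(C)nc3ccccc23)cc1C(=O)OCCCC[Se]C#N` stands well apart at 662 nM. Compound 4 `COc1ccc(N(C)c2nc(C)nc3ccccc23)cc1OCCCC[Se]C#N` alters compound 3 on a saturated chain carbon, two bonds along the chain from an oxygen on an aromatic ring: a group of 5 heavy atoms (3 carbon, 1 nitrogen, 1 selenium; no ring) in place of a group of 3 heavy atoms (1 carbon, 1 nitrogen, 1 selenium; no ring), on a saturated chain carbon, two bonds along the chain from an oxygen on an aromatic ring. Within the data shown here, three measured steps bear on this, and all three change the group on an aromatic carbon. A larger group gave a large 24-fold higher number from compound 1 to compound 2 (1.37 log units; beyond the scatter), and the reverse appears in a 37-fold lower number from compound 2 to compound 3 (1.57 log units; beyond the scatter). Yet a 1.6-fold lower number from compound 1 to compound 3 (0.19 log units; within the scatter) also enlarges the group and stays within the scatter, so size alone is a weak guide. A moderate rise is therefore expected, an estimated 3.3-fold higher number from compound 3 to compound 4 (0.52 log units; beyond the scatter). Compound 4 is estimated at 60 nM, with an expected range of 15 nM to 300 nM.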

Compound 4, half-maximal inhibitory concentration: 512 nM
For compound 4 the middle estimate is 8.5-fold (0.93 log units) below the measured one, and the stated range ends below it.
By their numbers in this assay, from the lowest: compounds 3 and 1 (each within the scatter of the next); then compounds 4 and 2 (each within the scatter of the next).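

In this assay a group of 5 heavy atoms in place of a group of 3 heavy atoms on this saturated chain carbon gives a large step (a 28-fold higher number from compound 3 to compound 4 (1.45 log units; beyond the scatter)), so a small enlargement of the chain can matter greatly. Compound 4 also stands clearly apart from compound 1 (an 18-fold higher number from compound 1 to compound 4 (1.26 log units; beyond the scatter)), which compound 3 did not. Removing the carbonyl from the longer group of compound 2 makes no clear difference (a 1.3-fold lower number from compound 2 to compound 4 (0.11 log units; within the scatter)).

Nothing available explains this loss. From the compounds shown here alone, whether a still longer chain, or an amine in place of the nitrile, would behave the same remains open.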